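The source may hold more compounds than are shown below. What is called first, only, known or untested is meant among the compounds shown, and "the series" means these compounds.

Four compounds sharing one core were compared in a functional assay on HepG2 cells (Homo sapiens) for cytotoxicity, read by MTT assay, with a stated time of 72 h; on this read-out lower numbers stand for stronger inhibition and higher numbers for weaker inhibition. Compound 1 `Cn1ccc2c(Oc3ccc(NC(=O)c4nn(-c5ccc(Br)cc5F)ccc4=O)cc3)ccnc21` gives 31200 nM in this assay. Compound 2 `Cn1ccc2c(Oc3ccc(NC(=O)c4nn(-c5ccc(Cl)c(F)c5)ccc4=O)cc3)ccnc21` differs from compound 1 in one place: 4-chloro-3-fluorophenyl in place of 4-bromo-2-fluorophenyl on an aromatic nitrogen. In this assay compound 2 gives > 60000 nM, which is a limit of the assay and not a number. From this follows an at least 1.9-fold higher number from compound 1 to compound 2 (0.28 log units; that floor lies within the scatter). Compound 3 `Cn1ccc2c(Oc3ccc(NC(=O)c4nn(-c5ccc(Br)cc5F)ccc4=O)cc3F)ccnc21` carries an altered core, in which (fluoro in place of hydrogen on an aromatic carbon), and in this assay compound 3 gives 24000 nM, so that a 1.3-fold lower number from compound 1 to compound 3 (0.11 log units; within the scatter). Compound 4 `Cn1ccc2c(Oc3ccc(NC(=O)c4nn(-c5ccc(Cl)c(F)c5)ccc4=O)cc3F)ccnc21` has not yet been measured in this assay; it stands to compound 3 as compound 2 stands to compound 1, the same change made at the same place: 4-chloro-3-fluorophenyl in place of 4-bromo-2-fluorophenyl on an aromatic nitrogen. Because the earlier step of that kind ended at the limit of > 60000 nM in this assay, at which 1 of the 3 values shown sits, the step from compound 3 to compound 4 is expected to be of a like size, a 2.3-fold higher number from compound 3 to compound 4 (0.36 log units; beyond the scatter), with a real chance that this assay again reports only a limit. Compound 4 is accordingly estimated at 55000 nM, within a range from 28000 nM to 120000 nM.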

Compound 4, half-maximal inhibitory concentration: 22100 nM
Compound 4: middle estimate off by 2.5-fold (0.40 log units), on the high side, outside the stated range (below it).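

In this assay, the exchange of 4-bromo-2-fluorophenyl for 4-chloro-3-fluorophenyl on the core of compound 3 gives a 1.1-fold lower number from compound 3 to compound 4 (0.04 log units; within the scatter), and set beside the same exchange on the core of compound 1 it reads: the same change on two cores in this assay, an at least 1.9-fold higher number (0.28 log units; that floor lies within the scatter) from compound 1 to compound 2 and a 1.1-fold lower number (0.04 log units; within the scatter) from compound 3 to compound 4; the limit leaves it open whether they differ. The fluoro in place of hydrogen on an aromatic carbon, taken with 4-chloro-3-fluorophenyl in place, gives an at least 2.7-fold lower number from compound 2 to compound 4 (0.43 log units; beyond the scatter), and set beside the same change with 4-bromo-2-fluorophenyl in place it reads: the same change on two cores in this assay, a 1.3-fold lower number (0.11 log units; within the scatter) from compound 1 to compound 3 and an at least 2.7-fold lower number (0.43 log units; beyond the scatter) from compound 2 to compound 4; the limit leaves it open whether they differ. Compound 2 gives > 60000 nM, which is a limit of the assay and not a number, so these compounds show neither that the exchange carries over unchanged from one core to the other nor that it fails to.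

The compounds shown leave open how other groups on the aromatic nitrogen, such as an unsubstituted phenyl or a pyridyl ring, would read in this assay. They also leave open whether an amine or a carboxylic acid on that aryl ring would move the numbers on either core.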